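A few compounds are considered here, and "the series" means these few. Any claim that something is new, unique, unknown or untested is made for them only; others in the source may bear on it.

In a functional assay on MDA-MB-231 cells (Homo sapiens) for antiproliferative activity, read by sulforhodamine B assay; a higher number here means a weaker inhibitor of growth, a lower number a stronger inhibitor of growth:
- Compound 1 `CC(C)CCCOc1cccc(O)c1C(=O)/C=C/c1ccc(O)cc1`: 3480 nM
- Compound 2 `CC(C)=CCOc1cccc(O)c1C(=O)/C=C/c1ccc(O)cc1`: > 30000 nM (a limit of the assay)
- Compound 3 `O=C(/C=C/c1ccc(O)cc1)c1c(O)cccc1OCC1CCCC1`: 3410 nM
- Compound 4 `CC(C)CCOc1cccc(O)c1C(=O)/C=C/c1ccc(O)cc1`: not yet measured

Compound 3 stands level with compound 1, as shown by a 1.0-fold lower number from compound 1 to compound 3 (0.01 log units; within the scatter). Compound 2 gives only a limit, > 30000 nM.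

The next change leads to compound 4: isobutyl in place of cyclopentyl on a saturated chain carbon bound to an oxygen on an aromatic ring. In words, this is isobutyl in place of cyclopentyl on a saturated chain carbon bound to an oxygen on an aromatic ring. Cut one bond further out, it reads cyclopentylmethyl to isopentyl.

For the measured compounds named here, two measured steps bear on this. The saturated side chains of compound 1 and compound 3 were interchangeable in this assay, which argues for a small change. Against that stands compound 2, with an at least 8.6-fold higher number from compound 1 to compound 2 (0.93 log units; beyond the scatter) and an at least 8.7-fold lower number from compound 2 to compound 3 (0.94 log units; beyond the scatter), so a modest loss cannot be excluded. A small rise is therefore expected, and the expected step is a 1.5-fold higher number from compound 3 to compound 4 (0.17 log units; within the scatter). For compound 4 the estimated value is 5000 nM, with an expected range of 2000 nM to 18000 nM.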

Compound 4, concentration for 50% growth inhibition: 10300 nM
Estimate against measurement, compound 4: 2.1-fold (0.31 log units) below; the range from low to high includes it.
By their numbers in this assay, from the lowest: compounds 3 and 1 (each within the scatter of the next); then compound 4. At a limit, above all of these: compound 2.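

In this assay, saturated side chains at this place proved not to be freely interchangeable: isobutyl in place of cyclopentyl gives a 3.0-fold higher number from compound 3 to compound 4 (0.48 log units; beyond the scatter). The same separation appears against the other saturated chain, with a 3.0-fold higher number from compound 1 to compound 4 (0.47 log units; beyond the scatter), so the isopentyloxy chain of compound 4 stands apart from the two chains that matched each other. Compound 2 remains a limit of the assay, so an at least 2.9-fold lower number from compound 2 to compound 4 (0.46 log units; beyond the scatter) is a bound and not a measured size, and it is the only reading available for that pair: the limit of > 30000 nM in this assay, at which 1 of the 4 values shown sits.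

The compounds shown leave open whether a longer chain than that of compound 1, or a cyclohexylmethoxy group, would lower the number further. They also do not show how an amine at the end of the chain would behave at this place.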